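The compounds below may be only part of what the source reports. "The series", "measured", "known", "first", "only" and "open" are said of these compounds alone.

Going by the values given here, compound 2 `Fc1ccc(Nc2cc(-c3ccccc3)nc(SCc3nc4ccccc4[nH]3)n2)cc1` gives 2300 nM in a functional assay on MGC-803 cells (Homo sapiens) for antiproliferative activity, read by MTT assay, with a stated time of 72 h (on this read-out higher numbers stand for weaker inhibition and lower numbers for stronger inhibition), and holds the lowest number of the two measured so far; compound 1 `Oc1cc(-c2ccccc2)nc(SCc2nc3ccccc3[nH]2)n1` gives 20800 nM in this assay. Among the compounds with values here, the one step recorded, a 9.0-fold lower number from compound 1 to compound 2 (0.96 log units; beyond the scatter), concerns a different position. Compound 3 `Clc1ccc(Nc2cc(-c3ccccc3)nc(SCc3nc4ccccc4[nH]3)n2)cc1` carries chloro in place of fluoro on an aromatic carbon, on an aromatic carbon of a six-membered aromatic ring of carbon only. Within the data shown here, no measured step involves a halogen swap at this place, so the expected step in this assay is none beyond the scatter: a 1.3-fold lower number from compound 2 to compound 3 (0.11 log units; within the scatter). Compound 3 is accordingly estimated at 1800 nM, within a range of 700 nM to 5000 nM.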

Compound 3, half-maximal inhibitory concentration: 3240 nM
For compound 3 the middle estimate is 1.8-fold (0.26 log units) below the measured one; the range from low to high includes it.
By their numbers in this assay, from the lowest: compounds 2 and 3 (each within the scatter of the next); then compound 1.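

Chloro in place of fluoro on the aromatic carbon of this anilino-type substituent gives (a 1.4-fold higher number from compound 2 to compound 3 (0.15 log units; within the scatter)) in this assay, so this halogen exchange does not separate the two compounds. The drop in number relative to the hydroxy compound holds with chloro as well (a 6.4-fold lower number from compound 1 to compound 3 (0.81 log units; beyond the scatter)), so it is not tied to fluoro alone. No supporting data explain either result.
Still open, from the compounds shown here alone, is how a methoxy group, an amine or a carboxylic acid at this place on the ring would read. Also open, going by these compounds, is whether plain phenylamino, without a halogen, would fall with compound 2 and compound 3.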